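This account rests on a few compounds, and the source may have more. Where it says the series, first, only, none or still open, it means among the compounds named here.

Measured so far:
- Compound 1 `CC1(c2ccc(Br)cc2)CC(S(=O)(=O)c2ccc(F)cc2)=C(c2ccc(/C(N)=N\O)cc2)O1` gives 10500 nM in an ADME assay on J774.A1 cells (Mus musculus) for cytotoxicity, read by MTT assay, with a stated time of 72 h; on this read-out higher numbers stand for lower toxicity in this test and lower numbers for higher toxicity in this test.
- Compound 2 `N/C(=N/O)c1ccc(C2=C(S(=O)(=O)c3ccc(F)cc3)CC(c3ccccc3)(c3ccccc3)O2)cc1` gives 10200 nM in this assay.

Compound 1 has the higher of the two numbers, but the two values lie within the scatter of each other, so the two compounds cannot be told apart in this assay. Going by the values given here, no step between two measured compounds that differ in a single place is available here.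

Compound 3 `CC1(c2ccc(-c3ccc(/C(N)=N\O)cc3)cc2)CC(S(=O)(=O)c2ccc(F)cc2)=C(c2ccc(/C(N)=N\O)cc2)O1` has not yet been measured. Compared with compound 1 it carries a group of 10 heavy atoms (7 carbon, 2 nitrogen, 1 oxygen; one six-membered aromatic ring of carbon only) in place of one bromine atom, on an aromatic carbon. Nothing in the two measured compounds speaks to this change, and both measured values sit close together, so no step beyond the scatter is expected in this assay in either direction. The value of compound 3 is estimated at 12000 nM, with a range from 5000 nM to 30000 nM, which corresponds to an expected step of a 1.1-fold higher number from compound 1 to compound 3 (0.06 log units; within the scatter).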

Compound 3, half-maximal cytotoxic concentration: 3940 nM
Compound 3: middle estimate off by 3.0-fold (0.48 log units), on the high side; measured number below the stated range.
By their numbers in this assay, from the lowest: compound 3; then compounds 2 and 1 (each within the scatter of the next).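

The aromatic carbon that carries the bromo group in compound 1 is a place where a change can move the result in this assay: putting the group of 10 heavy atoms there in place of bromine gives a 2.7-fold lower number from compound 1 to compound 3 (0.43 log units; beyond the scatter). A lower number stands for higher toxicity in this test, so this exchange makes the compound modestly more toxic to these cells. No measurement at hand accounts for this step.

The exchange brings in an aromatic ring and hydrogen-bond donors and acceptors all at once, and the compounds shown cannot separate what each of these contributes. A plain phenyl ring or a chlorine atom at this place, or an amine on the new ring, would remain to be compared with compound 1.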